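Adding a Fluoro to the Anilino Ring of Compound 3

A few compounds are considered here, and "the series" means these few. Any claim that something is new, unique, unknown or untested is made for them only; others in the source may bear on it.

Compound 1 `Cc1ccccc1Nc1nc2nonc2nc1Nc1ccccc1C` gives 2300 nM in an assay on mitochondria from L6 cells (Rattus norvegicus) for activation, with a stated time of 90 min; on this read-out higher numbers stand for an effect only at larger amounts of compound and lower numbers for an effect already at smaller amounts.
Compound 2 `Cc1cccc(Nc2nc3nonc3nc2Nc2cccc(C)c2)c1` gives 2100 nM in this assay.
Compound 3 `Fc1ccccc1Nc1nc2nonc2nc1Nc1ccccc1` gives 2200 nM in this assay.

Among these three numbers compound 3 stands second highest, yet its distance to compound 1 and to compound 2 lies within the scatter, so the three measured compounds cannot be told apart on this read-out. Compound 4 `Fc1cccc(Nc2nc3nonc3nc2Nc2ccccc2F)c1` differs from compound 3 by fluoro in place of hydrogen on an aromatic carbon. Among the compounds with values here, no measured pair differs in only one place, so there is no single step to lean on; what the three measured values do show is that different groups on the anilino rings have left the read-out unchanged so far. The step expected in this assay is a 1.1-fold lower number from compound 3 to compound 4 (0.04 log units; within the scatter), none beyond the scatter in either direction. Compound 4 is expected to give about 2000 nM in this assay, within a range from 900 nM to 4500 nM.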

Compound 4, half-maximal effective concentration: 190 nM
The estimate for compound 4 lay 11-fold (1.02 log units) above the measured number, and the stated range ends above it.
By their numbers in this assay, from the lowest: compound 4; then compounds 2, 3 and 1 (each within the scatter of the next).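

Replacing hydrogen with fluoro, the change from phenyl to 3-fluorophenyl, gives a 12-fold lower number from compound 3 to compound 4 (1.06 log units; beyond the scatter) in this assay, the first single-place step available in this series. This shows that the read-out is not indifferent to the anilino rings: a single fluorine atom on an aromatic carbon, meta to a large group, is enough to move the number well beyond the scatter, so that an effect appears at smaller amounts of compound. Nothing measured here accounts for this shift.

The compounds shown leave open whether the step belongs to fluoro itself or would also follow from a chloro, methoxy or trifluoromethyl group in the same place. They also leave open whether fluoro elsewhere on this ring would give a step of similar size.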